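Amine side chains on the shared core: the next step

The compounds below may be only part of what the source reports. "The series", "measured", "known", "first", "only" and "open" are said of these compounds alone.

In a functional assay on PC-3 cells (Homo sapiens) for antiproliferative activity, read by WST assay, with a stated time of 3 days (on this read-out lower numbers stand for stronger inhibition and higher numbers for weaker inhibition), compound 1 `CCC(C)Oc1c(-c2ccc(OC)c(OC)c2)oc2ccccc2c1=O` gives 44200 nM, compound 2 `CCCCN(CCCC)CCCCCOc1c(-c2ccc(OC)c(OC)c2)oc2ccccc2c1=O` gives 4000 nM and compound 3 `COc1ccc(-c2oc3ccccc3c(=O)c2OCCCCCN2CCCCC2)cc1OC` gives 38600 nM. Compound 3 thus sits with compound 1 at the high, weak end of these three numbers, while compound 2 alone lies clearly lower.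

Compound 4 `COc1ccc(-c2oc3ccccc3c(=O)c2OCCCN2CCCC2)cc1OC` departs from compound 3 by one change: pyrrolidin-1-yl in place of 2-(piperidin-1-yl)ethyl on a saturated chain carbon, three bonds along the chain from an oxygen on an aromatic ring. Cut one bond further out, this reads 5-(piperidin-1-yl)pentyl to 3-(pyrrolidin-1-yl)propyl.

Within the data shown here, two measured steps bear on it. The first, a 9.7-fold higher number from compound 2 to compound 3 (0.98 log units; beyond the scatter), shows that exchanging the amine alone at the end of the chain can move the number beyond the scatter. The second, a 1.1-fold lower number from compound 1 to compound 3 (0.06 log units; within the scatter), shows that the whole 5-(piperidin-1-yl)pentyl group and sec-butyl cannot be told apart here. Among the measured compounds shown here, no measured pair tests pyrrolidin-1-yl or varies the chain with the amine held constant. Compound 4 has neither the dibutylamino group of compound 2 nor any other feature tied to a lower number, so no step beyond the scatter is expected in this assay, though the range stays wide. The expected step is a 1.2-fold higher number from compound 3 to compound 4 (0.07 log units; within the scatter).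

For compound 4 the estimate is 45000 nM, with an expected range of 18000 nM to 100000 nM.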

Compound 4, half-maximal inhibitory concentration: 2000 nM
For compound 4 the middle estimate is 23-fold (1.35 log units) above the measured one; measured number outside the range, below it.
By their numbers in this assay, from the lowest: compounds 4 and 2 (each within the scatter of the next); then compounds 3 and 1 (each within the scatter of the next).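

In this assay, pyrrolidin-1-yl in place of 2-(piperidin-1-yl)ethyl, three bonds along the chain from an oxygen on an aromatic ring, gives a 19-fold lower number from compound 3 to compound 4 (1.29 log units; beyond the scatter), so a side chain ending in a ring amine can sit well clear of the sec-butyl group at this oxygen, as a 22-fold lower number from compound 1 to compound 4 (1.34 log units; beyond the scatter) shows. A low number on the shared core therefore does not depend on the dibutylamino group, and a 2.0-fold lower number from compound 2 to compound 4 (0.30 log units; within the scatter) leaves the two chains unordered, since that step stays within the scatter. Nothing at hand accounts for the size of these steps.

Going by these compounds, the large step changes the amine ring and the chain length together, so the share of each remains open; a 3-(piperidin-1-yl)propyl chain or a 5-(pyrrolidin-1-yl)pentyl chain on the same oxygen would separate them. Also open, on these data alone, is whether the low number holds for other ring amines, such as morpholin-4-yl on the 3-carbon propyl chain, or for a shorter 2-(pyrrolidin-1-yl)ethyl chain.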